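The compounds below may be only part of what the source reports. "The series", "measured", "known", "first", "only" and "open" are said of these compounds alone.

Working notes on the series.

Compound 1 `CCCCCCOc1ccc(-n2cnnc2CC)cc1` carries an ethyl group on its core; in a functional assay on the whole organism (strain C57B/6) with Mus musculus as the target, in the maximal electroshock model (a higher number here means that more compound is needed for the effect, a lower number that less compound is needed), compound 1 gives 13.2 mg/kg. Compound 2 `CCCCCCOc1ccc(-n2cnnc2-c2ccccc2Cl)cc1` gives 13.2 mg/kg in this assay, and compound 3 `CCCCCCOc1ccc(-n2cnnc2-c2ccc(C)cc2)cc1` gives 11.4 mg/kg. Compound 1 thus stands level with compound 2 at the digits shown, the two together at the high end of the three numbers; the step of no change at the digits printed from compound 1 to compound 2 (within the scatter) and the step of a 1.2-fold lower number from compound 1 to compound 3 (0.06 log units; within the scatter) both lie within the scatter, as does a 1.2-fold lower number from compound 2 to compound 3 (0.06 log units; within the scatter).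

Compound 4 `CCCCCCOc1ccc(-n2cnnc2CCc2ccccc2)cc1` is not yet measured. It differs from compound 1 by phenyl in place of hydrogen on a saturated chain carbon, two bonds along the chain from an aromatic carbon. The measured steps that bear on this are those from compound 1, where ethyl was exchanged for an aromatic group: no change at the digits printed from compound 1 to compound 2 (within the scatter) and a 1.2-fold lower number from compound 1 to compound 3 (0.06 log units; within the scatter). Adding a phenyl on the ethyl chain is expected to behave likewise, so no step beyond the scatter in this assay is expected, a 1.1-fold lower number from compound 1 to compound 4 (0.02 log units; within the scatter). Compound 4 is therefore estimated at 12.5 mg/kg in this assay, within 7 mg/kg to 22 mg/kg.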

Compound 4, dose for half-maximal effect: 27.4 mg/kg
Estimate against measurement, compound 4: 2.2-fold (0.34 log units) below, outside the stated range (above it).
By their numbers in this assay, from the lowest: compounds 3, 1 and 2 (each within the scatter of the next); then compound 4.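

In this assay, going by these compounds alone, this position does not accept every larger group alike: phenyl in place of hydrogen on a saturated chain carbon, two bonds along the chain from an aromatic carbon, gives a 2.1-fold higher number from compound 1 to compound 4 (0.32 log units; beyond the scatter) and is the first step to pass the scatter, though only a modest one. Phenethyl also separates from both aromatic groups held on the same aromatic carbon, with a 2.4-fold higher number from compound 3 to compound 4 (0.38 log units; beyond the scatter) and a 2.1-fold higher number from compound 2 to compound 4 (0.32 log units; beyond the scatter) as steps, so the size of the added group alone does not set the number among these compounds. No measurement at hand offers an explanation for this shift.

On these data alone, whether the phenyl itself or its distance along the chain governs the step stays open. Benzyl, phenylpropyl or an amine at the end of the ethyl chain would help to separate the two.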